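Nitrooxy Entering the Chain Carbon: Expected Edema Inhibition

The source may hold more compounds than are shown below. What is called first, only, known or untested is meant among the compounds shown, and "the series" means these compounds.

Within the data shown here, compound 2 `Cc1ccc(S(=O)(=O)Nn2c(C)nc3ccccc3c2=O)cc1` stands highest of the two compounds measured in a functional assay on the whole organism (strain Sprague-Dawley) for inhibition, with Rattus norvegicus as the target, read by paw edema, with stated times of 30 min and 3 h, at a dose of 80 mg/kg by the oral route; on this read-out higher numbers stand for more inhibition at the one dose given (going by the name of the read-out) and lower numbers for less inhibition; at the single oral dose compound 2 gives 83.9%. Compound 1 `O=c1c2ccccc2nc(CO[N+](=O)[O-])n1NS(=O)(=O)c1ccccc1`, which carries a nitrooxy group on its chain carbon and has no methyl on the sulfonyl-bearing ring, gives 55%, a value beyond the scatter below that of compound 2. Compound 3 `Cc1ccc(S(=O)(=O)Nn2c(CO[N+](=O)[O-])nc3ccccc3c2=O)cc1` is not yet measured. It differs from compound 2 by nitrooxy in place of hydrogen on a saturated chain carbon bound to an aromatic carbon. Among the measured compounds shown here, no measured pair shows this change alone, so its size is uncertain. Given that compound 1, the only measured compound bearing nitrooxy, gives 55%, a downward step beyond the scatter is expected from compound 2 to compound 3, estimated as a number 21.9 percentage points lower from compound 2 to compound 3 (beyond the scatter). Compound 3 is expected to give 62%, within a range from 45% to 78%. Compound 1 also differs from compound 3 in another place, so this expectation rests on one comparison only.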

Compound 3, a percentage reported as inhibition, in the whole organism at one dose (the size of the read-out at that dose, not a potency): 71.6%
The estimate for compound 3 lay 9.6 percentage points below the measured number; the measured number falls inside the stated range.
By their numbers in this assay, from the lowest: compound 1; then compound 3; then compound 2.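

In this assay the pair that differs at the chain carbon alone shows a number 12.3 percentage points lower from compound 2 to compound 3 (beyond the scatter) for nitrooxy in place of hydrogen on a saturated chain carbon bound to an aromatic carbon, so this change lowers edema inhibition at this position when the methyl on the sulfonyl-bearing ring is present. The methyl in place of hydrogen on an aromatic carbon, read with nitrooxy present on both sides, goes with a number 16.6 percentage points higher from compound 1 to compound 3 (beyond the scatter) and so has a step of its own in this series. Nothing measured here speaks to the origin of either step.

Each change is read only once, on one background and at one oral dose. Going by these compounds, whether a hydroxy group, a carboxylic acid or a longer chain carrying the nitrooxy group on this carbon would keep more of the inhibition stays open.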